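Chloromethylbenzyl purines: SK-MEL-2 cytotoxicity, amino variant

The source may hold more compounds than are shown below. What is called first, only, known or untested is meant among the compounds shown, and "the series" means these compounds.

Measured so far:
- compound 1, `ClCc1ccc(Cn2cnc3c(Cl)ncnc32)cc1`: > 100000 nM
- compound 2, `ClCc1cccc(Cn2cnc3ncnc(Cl)c32)c1`: 6760 nM
- compound 3, `ClCc1cccc(Cn2cnc3c(Cl)ncnc32)c1`: > 100000 nM

In a functional assay on SK-MEL-2 cells (Homo sapiens) for cytotoxicity, read by sulforhodamine B assay, with a stated time of 48 h (on this read-out lower numbers stand for higher toxicity in this test and higher numbers for lower toxicity in this test), compound 2 gives 6760 nM. Compound 1 reaches only a limit of the test, > 100000 nM. Compound 3 likewise reaches only a limit, > 100000 nM; it sits at the limit of > 100000 nM in this assay, at which 2 of the 3 values shown sit, and so no number places it against compound 2.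

Compound 4, `Nc1nc(Cl)c2ncn(Cc3cccc(CCl)c3)c2n1`, is the next entry. It differs from compound 3 by amino in place of hydrogen on an aromatic carbon between two ring nitrogen atoms, meta to a chloro group.

Within the data shown here, no measured pair in this set isolates this change, so no step size can be taken from the data. Compound 3 provides only a limit, so the direction of the step cannot be fixed either; the working assumption is no change beyond the scatter, with the chance of a numbered value kept open. Compound 4 is expected at 80000 nM, within 20000 nM to 300000 nM. The expected step is an at least 1.2-fold lower number from compound 3 to compound 4 (0.09 log units; that floor lies within the scatter), and the test may again return only a limit for compound 4.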

Compound 4, concentration lethal to 50% of the cells: > 100000 nM
Compound 4 was reported as a limit (the forecaster's own chance of this, stated with the estimate: 55%); middle value at least 1.2-fold (0.09 log units) away from the limit.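

Compound 3 and compound 4 both stand at a limit of the test, so no step can be read between them: the limit of > 100000 nM in this assay, at which 3 of the 4 values shown sit.

The compounds shown leave open whether amino in place of hydrogen on an aromatic carbon changes the cytotoxicity read-out at all, and in which direction.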